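The source may report more compounds than this note shows. Statements on the series, on what has been measured and on what is new or still open speak of the compounds shown alone.

Compound 1 `Cc1cc(C)c(S(=O)(=O)N[C@@H](CNC(=O)CO[C@@H]2C[C@@H](CNc3ccccn3)N(CCCc3ccccc3)C2)C(=O)O)c(C)c1` and compound 2 `Cc1cc(C)c(S(=O)(=O)N[C@@H](CNC(=O)CO[C@@H]2C[C@@H](CNc3ccccn3)N(C(=O)CC(C)(C)C)C2)C(=O)O)c(C)c1` share one core and differ in a single group. In an assay on a protein complex for inhibition of integrin alpha-5/beta-1 (Homo sapiens), read by ELISA (a lower number here means a stronger inhibitor, a higher number a weaker inhibitor), compound 1 gives 670 nM, and compound 2 gives 6 nM. The step of a 110-fold lower number from compound 1 to compound 2 (2.05 log units; beyond the scatter) is beyond the scatter, so compound 2 stands as the stronger of the two measured compounds. Compound 3 `Cc1cc(C)c(C(=O)N[C@@H](CNC(=O)CO[C@@H]2C[C@@H](CNc3ccccn3)N(C(=O)CC(C)(C)C)C2)C(=O)O)c(C)c1` carries (2,4,6-trimethylphenyl)carbonyl in place of (2,4,6-trimethylphenyl)sulfonyl on an amine nitrogen. Within the data shown here, the only measured step concerns a different group, so no measured step bears on this change, and the expectation is uncertain. The step of a 5.0-fold higher number from compound 2 to compound 3 (0.70 log units; beyond the scatter) is estimated to be a modest weakening. Compound 3 is expected to give 30 nM, within 5 nM to 200 nM.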

Compound 3, half-maximal inhibitory concentration: 1.6 nM
Compound 3: middle estimate off by 19-fold (1.27 log units), on the high side; measured number outside the range, below it.
By their numbers in this assay, from the lowest: compound 3; then compound 2; then compound 1.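

The step of a 3.8-fold lower number from compound 2 to compound 3 (0.57 log units; beyond the scatter) in this assay shows that (2,4,6-trimethylphenyl)sulfonyl is not required on this amine nitrogen for strong inhibition, since (2,4,6-trimethylphenyl)carbonyl gives the stronger inhibitor here. Among these compounds, it is also the first measured change at this place, as the earlier step concerned a different group on a ring nitrogen. Nothing available explains why the carbonyl compound is the stronger one.

As far as these compounds go, how a plain phenyl or a pyridine ring would compare on this carbonyl stays open. So does whether the carbonyl keeps its advantage with 3-phenylpropyl on the ring nitrogen.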